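Propoxy to Ethylamino on the Carbonyl of Compound 1

The source may hold more compounds than are shown below. What is called first, only, known or untested is meant among the compounds shown, and "the series" means these compounds.

Compound 1 `CCCOC(=O)c1ccc(COC(COCc2ccc(OC)cc2)Cn2ccnc2)cc1` is the reference point of this small set. Among the measured compounds shown here, in a functional assay for inhibition of Thromboxane-A synthase (Homo sapiens) (on this read-out higher numbers stand for weaker inhibition and lower numbers for stronger inhibition), compound 1 gives 180 nM, the lowest of the three numbers measured so far. Compound 2 `COc1ccc(COCC(Cn2ccnc2)OCc2ccc(C(=O)Oc3ccccc3)cc2)cc1` gives 560 nM, and compound 3 `COc1ccc(COCC(Cn2ccnc2)OCc2ccc3c(c2)COC3=O)cc1` gives 6200 nM, the furthest from compound 1 of the three.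

Compound 4 `CCNC(=O)c1ccc(COC(COCc2ccc(OC)cc2)Cn2ccnc2)cc1` is not yet measured. It differs from compound 1 in one place: ethylamino in place of propoxy on a carbonyl carbon. For the measured compounds named here, no measured step covers this particular change. Going by the values given here, the one step that touches the same carbonyl group is a 3.1-fold higher number from compound 1 to compound 2 (0.49 log units; beyond the scatter), and it shows that an exchange on that oxygen can move the number beyond the scatter while staying modest in size. The propoxy to ethylamino exchange is of a different kind, so this is only a loose guide.

He therefore expects a modest shift toward a higher number, a 1.9-fold higher number from compound 1 to compound 4 (0.29 log units; within the scatter), and estimates compound 4 at 350 nM, within a range from 100 nM to 1200 nM.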

Compound 4, half-maximal inhibitory concentration: 12400 nM
Beside the measured number, compound 4's estimate is 35-fold (1.55 log units) below it, and the stated range ends below it.
By their numbers in this assay, from the lowest: compound 1; then compound 2; then compounds 3 and 4 (each within the scatter of the next).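

In this assay, the group on this carbonyl carbon turns out to matter far more than the earlier step from propoxy to phenoxy showed: ethylamino in place of propoxy gives a 69-fold higher number from compound 1 to compound 4 (1.84 log units; beyond the scatter), and ethylamino in place of phenoxy gives a 22-fold higher number from compound 2 to compound 4 (1.35 log units; beyond the scatter). Both of these steps are large, while the step between the two esters, a 3.1-fold higher number from compound 1 to compound 2 (0.49 log units; beyond the scatter), is modest, so here the exchange of either oxygen-linked group for ethylamino outweighs the difference between propoxy and phenoxy. Among the compounds shown here, nothing available explains why this exchange moves the number so far.

The exchange alters both the linking atom and the chain, so compound 4 cannot show which of the two accounts for its higher number. The compounds shown leave open how propylamino, ethoxy or a carboxylic acid at this carbonyl carbon would read.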